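The source may hold more compounds than are shown below. What is called first, only, known or untested is meant among the compounds shown, and "the series" means these compounds.

Working notes on the series. Compound 2 `COc1cc(C)cc(-c2nn(CC#N)cc2-c2ccnc(-c3ccc(N(C)C)cc3)c2)c1` has the lower of the two numbers in hand: in a functional assay on NCI-H460 cells (Homo sapiens) for inhibition, read by sulforhodamine B assay, with a stated time of 48 h (a lower number here means a stronger inhibitor of growth, a higher number a weaker inhibitor of growth), compound 2 gives 168 nM, while compound 1 `Cc1cc(O)cc(-c2nn(CC#N)cc2-c2ccnc(-c3ccc(Oc4ccccc4)cc3)c2)c1` in this assay gives 3580 nM, a gap that lies beyond the scatter. Compound 3 `Cc1cc(O)cc(-c2nn(CC#N)cc2-c2ccnc(-c3ccc(N(C)C)cc3)c2)c1` is not yet measured. It differs from compound 2 in one place: hydrogen in place of methyl on an oxygen on an aromatic ring. Among the measured compounds shown here, no measured pair in this set isolates that change, so the size of the step rests on judgement alone. For a change of one carbon at the edge of the shared core, a small step is expected, not clearly in either direction and likely within the scatter, with a modest loss held as the more probable side. Compound 3 is therefore estimated at 260 nM in this assay, with a range of 80 nM to 850 nM, which would mean an expected step of a 1.5-fold higher number from compound 2 to compound 3 (0.19 log units; within the scatter).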

Compound 3, concentration for total growth inhibition: 10200 nM
The estimate for compound 3 lay 39-fold (1.59 log units) below the measured number, and the stated range ends below it.
By their numbers in this assay, from the lowest: compound 2; then compound 1; then compound 3.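

In this assay, among the compounds shown here, methoxy to hydroxy on the 3-methoxy-5-methylphenyl group gives a large step, a 61-fold higher number from compound 2 to compound 3 (1.78 log units; beyond the scatter) and so the methyl on this oxygen, which no earlier pair isolated, carries great weight for growth inhibition. With hydroxy held in place, dimethylamino in place of phenoxy on an aromatic carbon gives a modest step, a 2.8-fold higher number from compound 1 to compound 3 (0.45 log units; beyond the scatter) and so the gain expected from dimethylamino does not appear alongside hydroxy. Nothing at hand gives a reason for either step.

Going by these compounds, whether an ethoxy group, with its longer chain on the oxygen, or an amine in place of the methoxy would keep the number seen for compound 2 stays open. Also open, on these data alone, is whether phenoxy and dimethylamino would differ by a similar step with methoxy in place of hydroxy.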